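Exocyclic hydantoin to thiazolidinedione at the chain carbon

The compounds below may be only part of what the source reports. "The series", "measured", "known", "first", "only" and "open" are said of these compounds alone.

Measured so far in an assay on membranes from Chem-1 cells for displacement of a labelled ligand from prostaglandin E2 receptor EP3 subtype (Homo sapiens), read by scintillation counting, with a stated time of 2 h; a lower number here means a stronger inhibitor, a higher number a weaker inhibitor:
- compound 1 `CC(C)C(/C=C1\NC(=O)NC1=O)c1ccc(-c2ccc3cccc(F)c3c2)[nH]c1=O` gives 43 nM
- compound 2 `CCC(/C=C1\OC(=O)NC1=O)(CC)c1ccc(-c2ccc3cccc(C(C)C)c3c2)[nH]c1=O` gives 120 nM
- compound 3 `CCC(CC)C(/C=C1\OC(=O)NC1=O)c1ccc(-c2ccc3cccc(F)c3c2)[nH]c1=O` gives 13 nM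

Compound 1 stands second highest of the three numbers in this assay. Compound 2 sits above it, beyond the scatter; compound 3 sits below it, also beyond the scatter. No pair among these three differs in one place only, so no single-point step can be read from the measured set; the three values show only that the series spans a range well beyond the scatter.

Compound 4 `CC(C)C(c1ccc(-c2ccc3cccc(F)c3c2)[nH]c1=O)C1SC(=O)NC1=O` is not yet measured. It differs from compound 1 by a group of 7 heavy atoms (3 carbon, 1 nitrogen, 2 oxygen, 1 sulfur; one five-membered non-aromatic ring with 2 hetero atoms) in place of a group of 8 heavy atoms (4 carbon, 2 nitrogen, 2 oxygen; one five-membered non-aromatic ring with 2 hetero atoms), on a saturated chain carbon bound to an aromatic carbon and a saturated chain carbon. For the measured compounds named here, the entering 2,4-dioxo-1,3-thiazolidin-5-yl ring is joined to the chain carbon without the exocyclic double bond that compound 1 carries, and the ring heteroatoms change, so nothing among the measured compounds speaks directly to this step.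

Working expectation: a modest rise in the number from compound 1 to compound 4, of a 2.1-fold higher number from compound 1 to compound 4 (0.32 log units; beyond the scatter), though a change within the scatter cannot be excluded. Compound 4 is accordingly estimated at 90 nM, with a range from 25 nM to 350 nM, resting only on the value of compound 1 43 nM and the uncertainty of the ring swap.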

Compound 4, inhibition constant: 25 nM
Compound 4: the middle estimate sits 3.6-fold (0.56 log units) above what was measured; measured number inside the range.
By their numbers in this assay, from the lowest: compounds 3, 4 and 1 (each within the scatter of the next, the first and the last beyond it); then compound 2.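

In this assay the 2,4-dioxo-1,3-thiazolidin-5-yl ring on the saturated chain carbon bound to an aromatic carbon and a saturated chain carbon gives a 1.7-fold lower number from compound 1 to compound 4 (0.24 log units; within the scatter) in place of the group of compound 1, and this step lies within the scatter. This position therefore tolerates a ring carrying sulfur, with 2 double bonds outside aromatic rings instead of 3 and with 1 hydrogen-bond donor and 3 hydrogen-bond acceptors instead of 2 of each, with no difference in the number that can be told from the scatter. No supporting measurement accompanies this step, so the result stands as an observation without an explanation.

The step changes the ring heteroatoms, the size of the entering group and the exocyclic double bond at once, so the share of each cannot be separated from these two compounds alone. From the compounds shown here alone, whether this chain carbon would also accept an open group such as a carboxylic acid in place of the ring, or a thiazolidinedione joined through an exocyclic double bond, remains open.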